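Swapping trifluoromethyl for trifluoromethoxy on a shared core

A few compounds are considered here, and "the series" means these few. Any claim that something is new, unique, unknown or untested is made for them only; others in the source may bear on it.

In a functional assay (aorta) for inhibition, with Rattus norvegicus as the target (a lower number here means that less compound is needed, a higher number that more compound is needed for the effect), compound 1 `O=C1C(Nc2ccc(Br)cc2)=CC(=O)c2ncccc21` gives 302 nM and compound 2 `O=C1C(Nc2ccc(C(F)(F)F)cc2)=CC(=O)c2ncccc21` gives 607 nM, so compound 2 stands within the usual scatter of compound 1. Compound 3 `O=C1C(Nc2ccc(OC(F)(F)F)cc2)=CC(=O)c2ncccc21` has trifluoromethoxy in place of trifluoromethyl on an aromatic carbon. Going by the values given here, the one measured step that bears on this change, with trifluoromethyl in place of bromo, is a 2.0-fold higher number from compound 1 to compound 2 (0.30 log units; within the scatter). That single step is small, so no change beyond the scatter is expected in this assay. The expected result is a 1.2-fold lower number from compound 2 to compound 3 (0.08 log units; within the scatter). For compound 3 the estimate is 500 nM, with an expected range of 200 nM to 1250 nM.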

Compound 3, half-maximal effective concentration: 603 nM
Compound 3: the middle estimate sits 1.2-fold (0.08 log units) below what was measured; the range from low to high includes it.
By their numbers in this assay, from the lowest: compounds 1, 3 and 2 (each within the scatter of the next).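

In this assay, the step from trifluoromethyl to trifluoromethoxy on this aromatic carbon gives a 1.0-fold lower number from compound 2 to compound 3 (0.00 log units; within the scatter), so the added oxygen leaves no visible mark on the number. The step from bromo to trifluoromethoxy gives a 2.0-fold higher number from compound 1 to compound 3 (0.30 log units; within the scatter), which places all three groups at this position within the scatter of one another. Nothing measured here explains why these groups read alike. As far as these compounds go, whether an amine, a carboxylic acid or a longer chain at this position would move the number beyond the scatter remains open.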